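The source may report more compounds than this note shows. Statements on the series, on what has been measured and on what is new or still open speak of the compounds shown alone.

Measured compounds:

Compound 1, `Cc1cc(=O)oc2cc(SC3CCOC3=O)ccc12`. In a functional assay on KB cells (Homo sapiens) for antiproliferative activity, read by sulforhodamine B assay, with a stated time of 72 h (a higher number here means a weaker inhibitor of growth, a lower number a stronger inhibitor of growth), compound 1 gives > 36100 nM, which is a limit of the assay rather than a number.
Compound 2, `Cc1cc(=O)oc2cc(SCc3cccc(C(F)(F)F)c3)ccc12`. In this assay compound 2 gives > 28500 nM, again a limit.
Compound 3, `CCc1oc2c(C)c(OC)ccc2c(=O)c1Br`. In this assay compound 3 gives > 33600 nM, also a limit.

Compound 3 therefore stands nowhere definite on the numbers shown: its result is a limit, and the two other results are limits as well (the limit of > 28500 nM in this assay, at which 1 of the 3 values shown sits, (the limit of > 33600 nM in this assay, at which 1 of the 3 values shown sits), (the limit of > 36100 nM in this assay, at which 1 of the 3 values shown sits)). For the measured compounds named here, none of the three compounds differs from another in only one place, so no measured step sets a scale for what a single change can do here.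

Compound 4, `CCc1oc2c(C)c(OCc3ccccc3)ccc2c(=O)c1Br`, differs from compound 3 by phenyl in place of hydrogen on a saturated chain carbon bound to an oxygen on an aromatic ring. Going by the values given here, with three limits and no measured step, the expectation rests on the observation that every compound so far sits at a limit; the step from compound 3 to compound 4 is estimated as an at least 1.1-fold lower number from compound 3 to compound 4 (0.04 log units; that floor lies within the scatter), that is, no change beyond the usual scatter. Compound 4 is therefore expected to give about 30000 nM in this assay, with a range from 8000 nM to 100000 nM, and most likely only a limit again.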

Compound 4, concentration for 50% growth inhibition: > 26700 nM
Compound 4 gave a limit, no number; the forecaster's own chance of this, stated with the estimate: 70%; the middle value is on the limit's open side.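

Compound 3 and compound 4 both gave only a limit, not a number, so the step from one to the other cannot be read. What the compounds shown leave open is whether any change to these structures gives a measurable growth inhibition in this assay.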